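Solubility notes: triazolyl replaces pyrazolyl on the shared core

The source may report more compounds than this note shows. Statements on the series, on what has been measured and on what is new or still open speak of the compounds shown alone.

Three compounds of the series have a number in a physicochemical assay for solubility; on this read-out lower numbers stand for lower solubility and higher numbers for higher solubility. Compound 1 `O=S(=O)(Nc1nccs1)c1ccc2c(c1)OCC[C@H]2c1ccc(C(F)(F)F)cc1-n1ccnn1` gives 154000 nM. Compound 2 `O=C1OCCN1c1cc(C(F)(F)F)ccc1[C@H]1CCOc2cc(S(=O)(=O)Nc3nccs3)ccc21` gives 295000 nM. Compound 3 `Cn1nccc1-c1cc(C(F)(F)F)ccc1[C@H]1CCOc2cc(S(=O)(=O)Nc3nccs3)ccc21` gives 83000 nM, the lowest of the three; against compound 1 the gap is within the scatter, against compound 2 it is beyond it. Among the compounds with values here, the one single-point step among them, a 3.6-fold lower number from compound 2 to compound 3 (0.55 log units; beyond the scatter), is modest.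

Compound 4 `O=S(=O)(Nc1nccs1)c1ccc2c(c1)OCC[C@@H]2c1ccc(C(F)(F)F)cc1-n1ccnn1` is not yet measured. Against compound 3 the change is 1H-1,2,3-triazol-1-yl in place of 1-methyl-1H-pyrazol-5-yl on an aromatic carbon. The step from compound 2 to compound 3 bears on it only loosely, since it swaps a different group at the same kind of position. More telling is compound 1, which also carries 1H-1,2,3-triazol-1-yl on the ring bearing the trifluoromethyl group and gives 154000 nM; the pair of compound 3 and compound 1 differs by an amount within the scatter.

The expected step in this assay is therefore small: compound 4 is estimated at 150000 nM, with a range of 70000 nM to 320000 nM. That estimate means a step of a 1.8-fold higher number from compound 3 to compound 4 (0.26 log units; within the scatter), expected to sit within the scatter of the measurement, because compound 1 with the same entering group gives 154000 nM.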

Compound 4, solubility: 171000 nM
Beside the measured number, compound 4's estimate is 1.1-fold (0.06 log units) below it, within the range that was stated.
By their numbers in this assay, from the lowest: compounds 3, 1, 4 and 2 (each within the scatter of the next, the first and the last beyond it).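

In this assay, within the data shown here, the 1H-1,2,3-triazol-1-yl group in place of 1-methyl-1H-pyrazol-5-yl on this aromatic carbon gives a 2.1-fold higher number from compound 3 to compound 4 (0.31 log units; beyond the scatter), a modest step and the first direct reading of this exchange. Among the ring groups at this position, the exchange of 2-oxo-1,3-oxazolidin-3-yl for 1H-1,2,3-triazol-1-yl gives a 1.7-fold lower number from compound 2 to compound 4 (0.24 log units; within the scatter), so this pair cannot be told apart in this assay, whereas the earlier step from the same oxazolidinone group to 1-methyl-1H-pyrazol-5-yl, a 3.6-fold lower number from compound 2 to compound 3 (0.55 log units; beyond the scatter), lay beyond the scatter. The drawn configuration at the saturated ring carbon can now be read on its own, and the step of a 1.1-fold higher number from compound 1 to compound 4 (0.05 log units; within the scatter) shows no separation between the two forms, a reading that rests on one fact: the fact that compounds 1 and 4 differ only in the configuration as drawn.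

On these data alone, that configuration comparison covers only the 1H-1,2,3-triazol-1-yl compounds, so it remains open whether the same holds with 1-methyl-1H-pyrazol-5-yl or 2-oxo-1,3-oxazolidin-3-yl at this position. All three groups shown here are rings, and how an open-chain amine or a carboxylic acid on this aromatic carbon would read in this assay also remains open.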